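A few compounds are considered here, and "the series" means these few. Any claim that something is new, unique, unknown or untested is made for them only; others in the source may bear on it.

Measured so far in a functional assay on PC-3 cells (Homo sapiens) for antiproliferative activity, read by MTT assay, with a stated time of 72 h; on this read-out lower numbers stand for stronger inhibition and higher numbers for weaker inhibition
compound 1 `O=C(N/N=C/c1ccc([N+](=O)[O-])cc1)Nc1ccc(Oc2ccnc3[nH]ccc23)c(F)c1` gives 150 nM
compound 2 `COc1ccc(/C=N/NC(=O)Nc2ccc(Oc3ccnc4[nH]ccc34)c(F)c2)c(OC)c1OC` gives 8970 nM

Compound 1 holds the lower of the two numbers, and the gap up to compound 2 lies beyond the scatter. Compound 3 `O=C(N/N=C/c1cc(Br)c(O)c(Br)c1)Nc1ccc(Oc2ccnc3[nH]ccc23)c(F)c1` is still unmeasured. It keeps the core of compound 1 and differs by 3,5-dibromo-4-hydroxyphenyl in place of 4-nitrophenyl on a carbon with a double bond to nitrogen and carries 3,5-dibromo-4-hydroxyphenyl in place of 4-nitrophenyl on a carbon with a double bond to nitrogen. For the measured compounds named here, no measured pair isolates a single change, so this replacement has no direct precedent. Compound 1 at 150 nM sits at the low end, while compound 2 at 8970 nM shows that a different group in this place can give a far higher number. A step towards weaker inhibition in this assay, beyond the scatter, is therefore expected. The estimated move is a 6.7-fold higher number from compound 1 to compound 3 (0.82 log units; beyond the scatter) upwards. For compound 3 the estimated value is 1000 nM with an expected range of 200 nM to 6000 nM in this read-out.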

Compound 3, half-maximal inhibitory concentration: "not active" (no number reported)
Compound 3 has no reported number here; no gap can be computed for the estimate.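

In this assay, for the compounds shown here, compound 3 gives "not active" (no number reported) and so no step from compound 1 can be read. No measured evidence bears on this result. The compounds shown leave open how 3,5-dibromo-4-hydroxyphenyl compares numerically with 4-nitrophenyl in this place.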